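The compounds below may be only part of what the source reports. "The series", "measured", "known", "first", "only" and "open" are said of these compounds alone.

Measured so far:
- compound 1, `COc1cc2c(=O)c(C(=O)c3ccc(C)cc3)cn(Cc3ccc(C(C)C)cc3)c2cc1OC`: 15500 nM in an ADME assay on Huh-7 cells (Homo sapiens) for cytotoxicity; a lower number here means a stronger inhibitor of growth, a higher number a weaker inhibitor of growth
- compound 2, `COc1cc2c(=O)c(C(=O)OCc3cccc(C)c3)cn(Cc3ccc(C(F)(F)F)cc3F)c2cc1OC`: 7300 nM in this assay

Only these two numbers exist in this assay. Compound 2 holds the lower of the two, and the gap to compound 1 lies beyond the usual scatter. Going by the values given here, compound 1 and compound 2 differ in more than one place, so no single step between them can be read off.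

Compound 3, `COc1cc2c(=O)c(C(=O)c3ccc(C)cc3)cn(Cc3ccc(C(F)(F)F)cc3F)c2cc1OC`, has not been measured. It is reached from compound 2 by 4-methylphenyl in place of (3-methylbenzyl)oxy on a carbonyl carbon whose other neighbour is an aromatic carbon. The same carbonyl group as in compound 3 is carried by compound 1, but compound 1 also bears a different substituent on the ring nitrogen, so its value cannot be taken as a direct reading of this change.

Among the compounds with values here, with no measured step for this exchange, the expected step of a 1.4-fold higher number from compound 2 to compound 3 (0.14 log units; within the scatter) is small, in either direction, and most likely within the scatter. Compound 3 is therefore estimated at 10000 nM, with a range from 3000 nM to 32000 nM.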

Compound 3, concentration for 50% growth inhibition: > 25000 nM
Compound 3: only a limit was reported; the forecaster's own chance of this, stated with the estimate: 25%; at least 2.5-fold (0.39 log units) between middle value and limit.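

In this assay compound 3 reads > 25000 nM, which is a limit and not a number, so every step ending at this compound gives only a floor, and this is the one value of the three at the limit: the limit of > 25000 nM in this assay, at which 1 of the 3 values shown sits.

Going by these compounds alone, on the carbonyl carbon, 4-methylphenyl in place of (3-methylbenzyl)oxy gives an at least 3.4-fold higher number from compound 2 to compound 3 (0.53 log units; beyond the scatter), the first single-place reading at this position, and it shows that with the 2-fluoro-4-(trifluoromethyl)phenyl group held constant, the group on the carbonyl carbon moves the number beyond the scatter. On the saturated chain carbon bound to an aromatic nitrogen, 2-fluoro-4-(trifluoromethyl)phenyl in place of 4-isopropylphenyl gives an at least 1.6-fold higher number from compound 1 to compound 3 (0.20 log units; that floor lies within the scatter), so this change has a floor that does not by itself clear the scatter, and its true size stays unresolved.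

On these data alone, how far either step extends past its floor remains open while compound 3 sits at a limit. Also open, as far as these compounds go, is whether (3-methylbenzyl)oxy keeps its lower number with 4-isopropylphenyl on the chain carbon, and what a benzylamino group or a shorter alkoxy chain on the carbonyl carbon would give.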